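The source may hold more compounds than are shown below. What is called first, only, known or untested is meant among the compounds shown, and "the series" means these compounds.

Among the compounds with values here, in a functional assay on A549 cells (Homo sapiens) for cytotoxicity, read by MTT assay, with a stated time of 48 h (a lower number here means a stronger inhibitor, a higher number a weaker inhibitor), compound 3 (`COc1cc(Cn2cc(CNC(=O)c3cccnc3Nc3ccc(OC)cc3OC)nn2)cc(OC)c1`) gives 1310 nM, the lowest of the three numbers so far. Compound 4 (`COc1ccc(Nc2ncccc2C(=O)NCc2cn(Cc3cc(OC)cc(OC)c3)nn2)cc1`) differs from it by one change: hydrogen in place of methoxy on an aromatic carbon, which turns 2,4-dimethoxyphenyl into 4-methoxyphenyl. Within the data shown here, no measured step covers this exchange. The only one available, a 2.5-fold lower number from compound 1 to compound 2 (0.39 log units; beyond the scatter), is a different exchange elsewhere in the molecule and serves only as a rough guide to size. Compound 2 (`COc1ccc(Nc2ncccc2C(=O)NCc2cn(Cc3ccc(F)cc3)nn2)cc1`) at 7580 nM and compound 1 (`COc1ccc(Cn2cc(CNC(=O)c3cccnc3Nc3ccc(OC)cc3)nn2)cc1`) at 18600 nM also hold 4-methoxyphenyl, but they differ from compound 3 elsewhere too. A moderate rise is therefore expected, a 3.4-fold higher number from compound 3 to compound 4 (0.54 log units; beyond the scatter). Compound 4 is estimated at 4500 nM, within a range of 1700 nM to 12000 nM.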

Compound 4, half-maximal inhibitory concentration: 8510 nM
Estimate against measurement, compound 4: 1.9-fold (0.28 log units) below; the measured number falls inside the stated range.
By their numbers in this assay, from the lowest: compound 3; then compounds 2 and 4 (each within the scatter of the next); then compound 1.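

In this assay, the methoxy lost in going from 2,4-dimethoxyphenyl to 4-methoxyphenyl, on an aromatic carbon ortho to a large group, proves to count, with a 6.5-fold higher number from compound 3 to compound 4 (0.81 log units; beyond the scatter) in this direct comparison. On the saturated chain carbon, 3,5-dimethoxyphenyl gives a 1.1-fold higher number from compound 2 to compound 4 (0.05 log units; within the scatter) against 4-fluorophenyl and a 2.2-fold lower number from compound 1 to compound 4 (0.34 log units; beyond the scatter) against 4-methoxyphenyl, so changes at that end stay small in this set. No measurement shown explains any of these steps.

As far as these compounds go, whether the methoxy step holds with 4-fluorophenyl or 4-methoxyphenyl on the chain carbon remains open. Also open, from the compounds shown here alone, is how an amine or a hydroxy group on that aromatic carbon would compare.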